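A few compounds are considered here, and "the series" means these few. Any claim that something is new, unique, unknown or untested is made for them only; others in the source may bear on it.

Among the two measured compounds, compound 2 `CCCCOc1cc(C(=O)NCCO)nn1-c1ccccc1` stands highest: in a functional assay on the whole organism (strain Wistar) for inhibition, with Rattus norvegicus as the target, read by paw edema, with stated times of 30 min and 3 h, at a dose of 100 mg/kg by the oral route (on this read-out lower numbers stand for less inhibition and higher numbers for more inhibition at the one dose given (going by the name of the read-out)), compound 2 gives 61.2%, while compound 1 `CCCCOc1cc(C(=O)NCC)nn1-c1ccccc1` gives 0% in this assay. For the measured compounds named here, the one measured step, a number 61.2 percentage points higher from compound 1 to compound 2 (beyond the scatter), rests on the hydroxy added two bonds along the chain from the amide-type nitrogen. Compound 3 `CCCCOc1cc(C(=O)N2CCCC2)nn1-c1ccccc1` carries pyrrolidin-1-yl in place of (2-hydroxyethyl)amino on a carbonyl carbon, so the hydroxy of compound 2 is gone and the amide-type nitrogen no longer bears a hydrogen. The step from compound 1 to compound 2 bears on this directly, since it is the hydroxy whose loss is in question, and because that step a number 61.2 percentage points higher from compound 1 to compound 2 (beyond the scatter) was large, a large fall is expected for compound 3, back toward the level of compound 1. Going by the values given here, no measured step shows what the pyrrolidin-1-yl ring itself does, so the expected step of a number 46.2 percentage points lower from compound 2 to compound 3 (beyond the scatter) is uncertain in size. Compound 3 is estimated at 15%, in the range 0% to 45%.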

Compound 3, a percentage reported as inhibition, in the whole organism at one dose (the size of the read-out at that dose, not a potency): 17.6%
Compound 3: the middle estimate sits 2.6 percentage points below what was measured; measured number inside the range.
By their numbers in this assay, from the lowest: compound 1; then compound 3; then compound 2.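

In this assay, pyrrolidin-1-yl in place of (2-hydroxyethyl)amino on a carbonyl carbon gives a number 43.6 percentage points lower from compound 2 to compound 3 (beyond the scatter), so this ring does not hold the level reached with the hydroxy-bearing chain. Set against ethylamino at the same place, the ring gives a number 17.6 percentage points higher from compound 1 to compound 3 (beyond the scatter), which shows that a group without a hydroxy can also raise the reading, though by a modest step only. No information is available on what lies behind either step.

The step to compound 3 removes the hydroxy and the amide hydrogen together, so the compounds shown do not separate the two, a question that a 3-hydroxypyrrolidin-1-yl group could address. From the compounds shown here alone, it also remains open whether a longer hydroxyalkyl chain, or an amine or a carboxylic acid in place of the hydroxy, would keep the reading of compound 2.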